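The source may hold more compounds than are shown below. What is called first, only, known or untested is meant among the compounds shown, and "the series" means these compounds.

Measured in an ADME assay on Raji cells (Homo sapiens) for cytotoxicity, with a stated time of 72 h; on this read-out lower numbers stand for an effect already at smaller amounts and higher numbers for an effect only at larger amounts of compound:

Compound 1 `Cc1cc(NC(=O)Nc2ccc(F)cc2)c2ccccc2n1`: > 25000 nM, a limit
Compound 2 `Cc1cc(NC(=O)Nc2cccc(F)c2)c2ccccc2n1`: > 25000 nM, a limit
Compound 3 `Cc1cc(NC(=O)Nc2ccccc2F)c2ccccc2n1`: > 25000 nM, a limit

The set offers no graded values, only this: the limit of > 25000 nM in this assay, at which 3 of the 3 values shown sit. Compound 3 therefore has no number of its own and stands level with its two companions only in the sense that all three share that limit.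

Compound 4 `Cc1cc(NC(=O)Nc2cc(F)ccc2F)c2ccccc2n1` differs from compound 3 by one change: fluoro in place of hydrogen on an aromatic carbon. The new fluoro joins the one already on the phenyl group.

Going by the values given here, three measured steps bear on this, as each moves the single fluoro around that ring. They are a step that the two limits leave unreadable from compound 1 to compound 2, a step that the two limits leave unreadable from compound 1 to compound 3 and a step that the two limits leave unreadable from compound 2 to compound 3. None of them has a readable size, so they give no measured effect of fluoro placement to carry over.

What they do show is that none of the three compounds yields a number in this assay. No step beyond the scatter is therefore expected in either direction, and a further report as a limit is the likeliest result. The expected step is a number no higher from compound 3 to compound 4 (the limit leaves the size open). For compound 4 the estimated value is 25000 nM, with an expected range from 12000 nM to 50000 nM.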

Compound 4, half-maximal effective concentration: > 25000 nM
Compound 4: no number, only a limit; the forecaster's own chance of this, stated with the estimate: 85%; the middle value sits exactly at the limit.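

Compound 4 gives > 25000 nM, which is a limit and not a number. Its steps from compound 3 and from compound 2 therefore cannot be read, and the set remains at a single shared limit: the limit of > 25000 nM in this assay, at which 4 of the 4 values shown sit.

The compounds shown leave open whether the number or placement of fluoro groups on the phenyl group makes any difference to this read-out.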